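This account rests on a few compounds, and the source may have more. Where it says the series, first, only, none or still open, it means among the compounds named here.

Series notes. Compound 1 `COc1cc2nc(N3CCN(C(C)=O)[C@H]4CCCC[C@H]43)nc(N)c2cc1OC` and compound 2 `CCCCCC(=O)N1CCN(c2nc(N)c3cc(OC)c(OC)cc3n2)[C@@H]2CCCC[C@@H]21` share one core and differ only on a saturated chain carbon bound to a carbonyl carbon. In a functional assay (strain Wistar) for antagonist activity at Alpha-1D adrenergic receptor (Rattus norvegicus), with a stated time of 30 min, in the presence of a further agent that is not named here (a lower number here means tighter binding, a higher number weaker binding), compound 1 gives 1700 nM, the highest of the two numbers; compound 2 gives 155 nM. Among the measured compounds shown here, the single measured step, an 11-fold lower number from compound 1 to compound 2 (1.04 log units; beyond the scatter), is large and beyond the scatter. Compound 3 `COc1cc2nc(N3CCN(C(=O)OCc4ccccc4)[C@H]4CCCC[C@H]43)nc(N)c2cc1OC` alters the same carbonyl carbon: benzyloxy in place of methyl on a carbonyl carbon. For the measured compounds named here, only the step from compound 1 to compound 2 bears on this change, and it points toward a lower number with a larger group at the carbonyl carbon, so a step of a 6.8-fold lower number from compound 1 to compound 3 (0.83 log units; beyond the scatter) is expected. Compound 3 is estimated at 250 nM, within 70 nM to 900 nM.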

Compound 3, dissociation constant: 240 nM
Compound 3: the middle estimate sits 1.0-fold (0.02 log units) above what was measured; measured number inside the range.
By their numbers in this assay, from the lowest: compounds 2 and 3 (each within the scatter of the next); then compound 1.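

In this assay the lower number at the carbonyl carbon is not confined to an alkyl chain: benzyloxy in place of methyl also gives a step beyond the scatter (a 7.1-fold lower number from compound 1 to compound 3 (0.85 log units; beyond the scatter)). Benzyloxy and pentyl at this carbon cannot be told apart (a 1.5-fold higher number from compound 2 to compound 3 (0.19 log units; within the scatter)), even though benzyloxy brings an aromatic ring and an added oxygen. No measurement here explains either step. On these data alone, whether a longer chain, a phenyl group attached directly or an aminomethyl group on the same carbonyl carbon gives a similar number remains open.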